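From methoxy to phenylsulfanyl: an estimate for compound 4

This account rests on a few compounds, and the source may have more. Where it says the series, first, only, none or still open, it means among the compounds named here.

Three methoxy compounds on a shared core provide the starting point. In a functional assay on the whole organism with Rattus norvegicus as the target (a higher number here means that more compound is needed for the effect, a lower number that less compound is needed), compound 3 (`CCOC(=O)C(=O)Nc1nc(-c2ccc(OC)cc2)cs1`) gives about 10 mg/kg and compound 2 (`CCOC(=O)C(=O)Nc1nc(-c2cccc(OC)c2)cs1`) gives about 20 mg/kg, and these two values lie within the usual scatter of each other. Compound 1 (`CCOC(=O)C(=O)Nc1nc(-c2ccccc2OC)cs1`) gives > 30 mg/kg, which is a limit of the assay and not a number. Compound 3 therefore has a single numerical neighbour, and the data do not separate it from compound 2.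

Compound 4 (`CCOC(=O)C(=O)Nc1nc(-c2ccc(Sc3ccccc3)cc2)cs1`) keeps the core of compound 3 and carries phenylsulfanyl in place of methoxy on an aromatic carbon, para to a large group: phenylsulfanyl in place of methoxy on an aromatic carbon. The measured compounds all carry methoxy, so none of them shows what a different group does at this place. The expectation in this assay is therefore cautious: a small move towards a higher number, within the scatter or only just beyond it. A result reported only as a limit also remains possible. The expected step is a 1.5-fold higher number from compound 3 to compound 4 (0.18 log units; within the scatter), with wide uncertainty. For compound 4 the estimated value is 15 mg/kg, with an expected range from 5 mg/kg to 40 mg/kg.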

Compound 4, dose for half-maximal effect: > 3 mg/kg
Compound 4: no number, only a limit; the forecaster's own chance of this, stated with the estimate: 25%; the middle value is on the limit's open side.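

In this assay compound 4 gives > 3 mg/kg, which is a limit of the assay and not a number, so no step can be read between compound 3 and compound 4. The compounds shown leave open whether phenylsulfanyl in place of methoxy on an aromatic carbon changes the number in this assay, and in which direction.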